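The source may hold more compounds than are shown below. What is called first, only, known or untested is meant among the compounds shown, and "the series" means these compounds.

Measured compounds in an assay on CHO cells for antagonist activity at transient receptor potential cation channel subfamily V member 1 (Homo sapiens), read by FLIPR; a lower number here means a stronger inhibitor, a higher number a weaker inhibitor:
- compound 1 `CC(C(=O)NCc1ccc(C(F)(F)F)cc1N1CCCCCCC1)c1ccc(NS(C)(=O)=O)c(F)c1` gives 2.8 nM
- compound 2 `CC(C)CCOc1cc(C(F)(F)F)ccc1CNC(=O)C(C)c1ccc(NS(C)(=O)=O)c(F)c1` gives 0.5 nM

Compound 2 stands lowest of the two numbers in this assay; the nearest is compound 1, and the difference is a 5.6-fold lower number from compound 1 to compound 2 (0.75 log units; beyond the scatter), a change of a group of 6 heavy atoms in place of a ring-containing group of 8 heavy atoms on an aromatic carbon of the shared core.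

Compound 3 `CC(C(=O)NCc1ccc(C(F)(F)F)cc1OCc1ccc(F)cc1)c1ccc(NS(C)(=O)=O)c(F)c1` is not yet measured. It differs from compound 2 in one place: 4-fluorophenyl in place of isobutyl on a saturated chain carbon bound to an oxygen on an aromatic ring. The ether oxygen on the aromatic carbon is kept; only the outer end of the chain is exchanged.

For the measured compounds named here, of the measured steps, only the step from compound 1 to compound 2 touches this side of the core, and it replaced the whole substituent rather than the outer end of the chain, so it bears on the change only loosely. Going by the values given here, no measured pair isolates an aryl for an alkyl at this position. The expected step in this assay is therefore small, a 1.4-fold higher number from compound 2 to compound 3 (0.15 log units; within the scatter), with no clear direction beyond the scatter. Compound 3 is estimated at 0.7 nM, within a range of 0.2 nM to 2.5 nM.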

Compound 3, inhibition constant: 0.5 nM
Beside the measured number, compound 3's estimate is 1.4-fold (0.15 log units) above it, and the stated range covers the measured number.
By their numbers in this assay, from the lowest: compounds 2 and 3 (each within the scatter of the next); then compound 1.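

Working notes on the series. In this assay, exchanging the outer end of the chain on the ether oxygen, 4-fluorophenyl in place of isobutyl, gives no change at the digits printed from compound 2 to compound 3 (within the scatter) and so does not separate a six-membered aromatic ring from an open chain at this place. Against the eight-membered ring of compound 1, the (4-fluorobenzyl)oxy group gives a 5.6-fold lower number from compound 1 to compound 3 (0.75 log units; beyond the scatter) in this assay and matches the size of the step to the isopentyloxy group, so the two oxygen-linked groups shown stand together, with compound 1 apart from both. Nothing measured here bears on why these two outer ends read alike.

Still open, as far as these compounds go, is whether this tolerance reaches outer ends of another kind, such as a carboxylic acid, a primary amine or a morpholine ring, or a longer chain than isopentyl. Also open, from the compounds shown here alone, is what the ether oxygen itself contributes, since a sulfur or a methylene link in its place would be needed to separate the oxygen from the outer end of the group.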